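From 2,5-dichlorophenyl to 4-nitrophenyl in compound 3

A few compounds are considered here, and "the series" means these few. Any claim that something is new, unique, unknown or untested is made for them only; others in the source may bear on it.

Measured in a functional assay on MGC-803 cells (Homo sapiens) for inhibition, read by MTT assay, with a stated time of 72 h; a higher number here means a weaker inhibitor, a lower number a stronger inhibitor:
Compound 1 `Cc1ccc(CSc2nc3nc(C)cc(N4CC[C@@H](C)[C@@H](N(C)c5ncnc6[nH]ccc56)C4)n3n2)cc1`: 5860 nM
Compound 2 `Cc1cc(N2CC[C@@H](C)[C@@H](N(C)c3ncnc4[nH]ccc34)C2)n2nc(SCc3cc(Cl)ccc3Cl)nc2n1`: 9850 nM

Among the compounds with values here, compound 2, at 9850 nM, lies within the scatter of compound 1, the only other measured compound. Within the data shown here, the gap between them is the one measured step, a 1.7-fold higher number from compound 1 to compound 2 (0.23 log units; within the scatter). That step put 2,5-dichlorophenyl in place of 4-methylphenyl on a saturated chain carbon bound to a sulfur.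

The next compound, compound 3 `Cc1cc(N2CC[C@@H](C)[C@@H](N(C)c3ncnc4[nH]ccc34)C2)n2nc(SCc3ccc([N+](=O)[O-])cc3)nc2n1`, changes the group at that same place, with 4-nitrophenyl in place of 2,5-dichlorophenyl on a saturated chain carbon bound to a sulfur. Among the measured compounds shown here, no measured compound carries 4-nitrophenyl, and a single step is thin evidence. For the measured compounds named here, still, the one earlier change at this place, a 1.7-fold higher number from compound 1 to compound 2 (0.23 log units; within the scatter), stayed within the scatter, and that is the only guide available.

In this assay the expected step is a 1.3-fold lower number from compound 2 to compound 3 (0.12 log units; within the scatter), with no step beyond the scatter expected and no firm direction. Compound 3 is estimated at 7500 nM, with an expected range of 2500 nM to 22000 nM.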

Compound 3, half-maximal inhibitory concentration: 27000 nM
Estimate against measurement, compound 3: 3.6-fold (0.56 log units) below; measured number above the stated range.
By their numbers in this assay, from the lowest: compounds 1 and 2 (each within the scatter of the next); then compound 3.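

In this assay, the group on the saturated chain carbon bound to a sulfur turns out to matter: a 2.7-fold higher number from compound 2 to compound 3 (0.44 log units; beyond the scatter) is a step beyond the scatter, with 4-nitrophenyl in place of 2,5-dichlorophenyl, whereas the two earlier compounds could not be told apart. The comparison with the methyl-bearing ring points the same way, since nitro in place of methyl on an aromatic carbon gives a 4.6-fold higher number from compound 1 to compound 3 (0.66 log units; beyond the scatter) and leaves the nitro compound as the weakest inhibitor of the three shown, although both steps are modest and this cell assay reports only an overall effect on the cells. No measurement at hand explains why this change weakens the result.

Three aromatic groups are too few to show whether the loss belongs to the nitro group alone or reflects a wider trend among groups at this place, and an unsubstituted phenyl ring would give a plain reference for all of them. On these data alone, it also remains open how an amine or a carboxylic acid on the ring, or a longer chain between the sulfur and the ring, would read in this assay.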